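This account rests on a few compounds, and the source may have more. Where it says the series, first, only, none or still open, it means among the compounds named here.

Measured so far:
- compound 1, `COc1cc(C)cc(-c2c(-c3ccnc(-c4ccc(C(C)=O)cc4)c3)cnn2CC#N)c1`: 60%
- compound 2, `Cc1cc(O)cc(-c2nn(CC#N)cc2-c2ccnc(-c3ccc(Oc4ccccc4)cc3)c2)c1`: 55%
- compound 3, `Cc1cc(O)cc(-c2nn(CC#N)cc2-c2ccnc(-c3ccc(N(C)C)cc3)c2)c1`: 28%

All three numbers come from a functional assay on SNB-19 cells (Homo sapiens) for cytotoxicity, read by sulforhodamine B assay, with a stated time of 48 h, tested at 1 uM; a lower number here means a stronger effect, a higher number a weaker effect of the compound at the concentration tested. Compound 1 gives the highest of the three; compound 2 sits within the scatter of it, so no order between those two can be read, while compound 3 lies well outside it. Going by the values given here, the only single-point step among the measured compounds is a number 27 percentage points lower from compound 2 to compound 3 (beyond the scatter), and it is the one change so far that moves the read-out beyond the scatter.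

Compound 4, `COc1cc(C)cc(-c2c(-c3ccnc(-c4ccc(N(C)C)cc4)c3)cnn2CC#N)c1`, is not yet measured. Against compound 1 it shows (dimethylamino in place of acetyl on an aromatic carbon). Among the compounds with values here, the group entering is the same one that enters from compound 2 to compound 3, although there it displaced phenoxy rather than acetyl, and the two pairs do not share the rest of their frame entirely; no measured step isolates what acetyl itself contributes. Within the data shown here, with a number 27 percentage points lower from compound 2 to compound 3 (beyond the scatter) as the only guide, a fall of comparable size is expected, a number 25 percentage points lower from compound 1 to compound 4 (beyond the scatter), with the uncertainty widened for the different leaving group. Compound 4 is therefore estimated at 35%, within a range from 18% to 55%.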

Compound 4, a percentage reported as activity, at one concentration (the size of the read-out at that concentration, not a potency): 36%
Compound 4: the middle estimate sits 1 percentage points below what was measured; the measured number falls inside the stated range.
By their numbers in this assay, from the lowest: compounds 3 and 4 (each within the scatter of the next); then compounds 2 and 1 (each within the scatter of the next).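

In this assay, replacing 4-acetylphenyl with 4-(dimethylamino)phenyl gives a number 24 percentage points lower from compound 1 to compound 4 (beyond the scatter), showing that this position, para to a large group, also responds when acetyl is the group leaving; with a number 27 percentage points lower from compound 2 to compound 3 (beyond the scatter), dimethylamino has now entered in two different frames, and both steps are beyond the scatter and run in the same direction, with no compound shown going against this. Acetyl and dimethylamino have the same count of heavy atoms and each counts as one hydrogen-bond acceptor, and neither has a hydrogen-bond donor, so these counts do not separate the pair, although the read-out does. No measurement shown bears on why the read-out moves with this change.

Still open, on these data alone, is whether the shift is particular to dimethylamino or extends to a primary amine or a morpholine ring at the same place, and how a carboxylic acid there would read. The two pairs also do not share the rest of their frame entirely, and each read-out comes from one concentration, so the steps give no measure of potency.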